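From pyrimidin-2-yl to ethyl on a carbonyl carbon

This account rests on a few compounds, and the source may have more. Where it says the series, first, only, none or still open, it means among the compounds named here.

In an ADME assay on microsomes from liver (Mus musculus) for pharmacokinetics, read by LC-MS, using NADPH, with stated times of 5 min, 15 min and 30 min, tested at 10 uM (a lower number here means slower removal, a higher number faster removal of the compound), compound 1 `C[C@H](NC(=O)c1ncccn1)c1ccc(NC(=O)N2CC(c3cccnc3)C2)cc1` gives 28.9 mL.min-1.g-1 while compound 2 `C[C@H](NC(=O)[C@@H]1CCCN1C)c1ccc(NC(=O)N2CC(c3cccnc3)C2)cc1` gives 40.8 mL.min-1.g-1 and the two cannot be told apart. The step between them is a 1.4-fold higher number from compound 1 to compound 2 (0.15 log units; within the scatter) for 1-methylpyrrolidin-2-yl in place of pyrimidin-2-yl on a carbonyl carbon. Compound 3 `CCC(=O)N[C@@H](C)c1ccc(NC(=O)N2CC(c3cccnc3)C2)cc1` has not yet been measured. It carries ethyl in place of pyrimidin-2-yl on a carbonyl carbon, so propanoyl stands where compound 1 has (pyrimidin-2-yl)carbonyl (ethyl in place of pyrimidin-2-yl on a carbonyl carbon). Going by the values given here, only one measured step bears on this change. Among the compounds with values here, it removes the same group from the same place but brings in a different one, and no measured compound carries ethyl there. Compound 2 gave 40.8 mL.min-1.g-1 within the scatter of compound 1, so no step beyond the scatter is expected for compound 3 in this assay, though a single case is thin support. The expected change is a 1.0-fold higher number from compound 1 to compound 3 (0.02 log units; within the scatter) on this estimate. For compound 3 the estimated value is 30 mL.min-1.g-1 with an expected range from 14 mL.min-1.g-1 to 60 mL.min-1.g-1.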

Compound 3, intrinsic clearance in microsomes: 31.4 mL.min-1.g-1
The estimate for compound 3 lay 1.0-fold (0.02 log units) below the measured number; the measured number falls inside the stated range.
By their numbers in this assay, from the lowest: compounds 1, 3 and 2 (each within the scatter of the next).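

In this assay, the step of a 1.1-fold higher number from compound 1 to compound 3 (0.04 log units; within the scatter) shows that replacing pyrimidin-2-yl with ethyl on this carbonyl carbon leaves the read-out within the scatter, even though one six-membered aromatic ring with 2 hydrogen-bond acceptors leaves and a group with no ring and 0 hydrogen-bond acceptors enters. The further step a 1.3-fold lower number from compound 2 to compound 3 (0.11 log units; within the scatter) is also within the scatter, so pyrimidin-2-yl, 1-methylpyrrolidin-2-yl and ethyl cannot be told apart at this position in these three compounds, where the earlier pair offered only a single replacement. No accompanying measurement gives a reason why these three compounds read alike.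

On these data alone, whether this holds for a carboxylic acid, a primary amine or a longer chain such as hexyl on the same carbonyl carbon remains open. The compounds shown also cannot tell how far the shared core, which is the same in all three, sets the read-out, as no change outside this one position is seen here.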